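The source may hold more compounds than are shown below. What is called first, only, known or untested is meant among the compounds shown, and "the series" means these compounds.

Of the compounds shown here, three that share one core have been measured in an assay on lysate for inhibition of 6-phosphofructo-2-kinase/fructose-2,6-bisphosphatase 3 (Homo sapiens), with stated times of 0.5 min and 45 min; a lower number here means a stronger inhibitor, a higher number a weaker inhibitor. Compound 1 `CN1CCC(CNS(=O)(=O)c2ccccc2Nc2cc(-c3ccc4ccn(C)c4c3)c3nccnc3c2)C1` gives 4640 nM, and compound 2 `CN(C)S(=O)(=O)c1ccccc1Nc1cc(-c2ccc3ccn(C)c3c2)c2nccnc2c1` gives 7670 nM. Compound 3 `CN(Cc1cncnc1)S(=O)(=O)c1ccccc1Nc1cc(-c2ccc3ccn(C)c3c2)c2nccnc2c1` reaches only a limit of the assay, > 100000 nM (the limit of > 100000 nM in this assay, at which 1 of the 3 values shown sits). The steps of an at least 21-fold higher number from compound 1 to compound 3 (1.33 log units; beyond the scatter) and an at least 13-fold higher number from compound 2 to compound 3 (1.11 log units; beyond the scatter) are both large, so compound 3 stands as the weakest of the three. Compound 4 `Cn1cc(CNS(=O)(=O)c2ccccc2Nc2cc(-c3ccc4ccn(C)c4c3)c3nccnc3c2)cn1` differs from compound 3 in one place: ((1-methyl-1H-pyrazol-4-yl)methyl)amino in place of methyl((pyrimidin-5-yl)methyl)amino on a sulfonyl sulfur. Compound 4 keeps an aromatic ring on the chain carbon, the feature that marked the step of an at least 13-fold higher number from compound 2 to compound 3 (1.11 log units; beyond the scatter), yet returns a hydrogen to the sulfonamide nitrogen as in compound 1. Compound 4 is therefore expected to move back toward compound 1 only partly, an at least 3.3-fold lower number from compound 3 to compound 4 (0.52 log units; beyond the scatter), with an estimated 30000 nM in this assay and a range from 5000 nM to 200000 nM.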

Compound 4, half-maximal inhibitory concentration: > 100000 nM
Compound 4: no number, only a limit (the forecaster's own chance of this, stated with the estimate: 35%); middle value at least 3.3-fold (0.52 log units) away from the limit.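

Compound 4 also sits at a limit of the assay, not at a number: the limit of > 100000 nM in this assay, at which 2 of the 4 values shown sit. Even with the hydrogen back on the sulfonamide nitrogen, 1-methyl-1H-pyrazol-4-yl on the chain carbon gives a large change from the 1-methylpyrrolidin-3-yl group, an at least 21-fold higher number from compound 1 to compound 4 (1.33 log units; beyond the scatter). The change from the dimethylamino group is large too, an at least 13-fold higher number from compound 2 to compound 4 (1.11 log units; beyond the scatter), while the step between the two compounds at the limit cannot be read.

The compounds shown leave open whether a simple phenyl ring or a saturated piperidin-4-yl ring on the same chain carbon would behave like the aromatic rings or like 1-methylpyrrolidin-3-yl. They also leave open how compound 3 and compound 4 rank against each other.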